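The source may hold more compounds than are shown below. What is called first, only, known or untested is meant among the compounds shown, and "the series" means these compounds.

Working notes on the series. Compound 1 `N[C@@H]1CCCN(c2nc(Nc3cccc(Cl)c3)nc3[nH]ccc23)C1` carries a 3-aminopiperidin-1-yl group on the shared core, and compound 2 `CC1(N)CCN(c2nc(Nc3cccc(Cl)c3)nc3[nH]ccc23)CC1` carries 4-amino-4-methylpiperidin-1-yl in its place. In an assay on isolated protein for inhibition of serine/threonine-protein kinase PAK 4 (Homo sapiens), read by filter binding, with a stated time of 20 min, tested at 2 uM (a higher number here means more inhibition at the concentration tested (going by the name of the read-out), a lower number less inhibition), compound 1 gives 72.5%. In this assay, for the measured compounds named here, compound 2 gives 35.5%, the lowest of the two numbers so far; the nearest number belongs to compound 1, and the step of a number 37 percentage points lower from compound 1 to compound 2 (beyond the scatter) is large and beyond the scatter. Compound 3 `NCC1CCCN(c2nc(Nc3cccc(Cl)c3)nc3[nH]ccc23)C1` is not yet measured. Its change from compound 2: 3-(aminomethyl)piperidin-1-yl in place of 4-amino-4-methylpiperidin-1-yl on an aromatic carbon. Going by the values given here, the single measured step that bears on this change is the large one between compound 1 and compound 2, which shows that exchanging one amine-bearing saturated ring for another can shift the read-out well beyond the scatter. Among the compounds with values here, compound 3 carries its amine on the one-carbon arm named in 3-(aminomethyl)piperidin-1-yl rather than on the ring as in compound 1, so no measured step matches it exactly. A rise from compound 2 is expected, its size uncertain, and the expected step is a number 19.5 percentage points higher from compound 2 to compound 3 (beyond the scatter). The estimate for compound 3 in this assay is 55%, within a range from 30% to 78%.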

Compound 3, a percentage reported as inhibition, at one concentration (the size of the read-out at that concentration, not a potency): 61%
Beside the measured number, compound 3's estimate is 6 percentage points below it, and the stated range covers the measured number.
By their numbers in this assay, from the lowest: compound 2; then compound 3; then compound 1.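

In this assay, a number 25.5 percentage points higher from compound 2 to compound 3 (beyond the scatter) shows that the read-out at this position, on an aromatic carbon next to the ring nitrogen, is not set by the counts alone, since 4-amino-4-methylpiperidin-1-yl and 3-(aminomethyl)piperidin-1-yl have the same heavy atoms, donors and acceptors. The a number 11.5 percentage points lower from compound 1 to compound 3 (beyond the scatter) adds a second comparison: lengthening the attachment of the amine to the one-carbon arm of 3-(aminomethyl)piperidin-1-yl costs less than the change to 4-amino-4-methylpiperidin-1-yl, and among these three compounds the two groups substituted at the 3-position of the piperidine both stand above compound 2, with none going against this. Nothing available on these compounds explains why the groups differ.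

The compounds shown leave open how a 4-aminopiperidin-1-yl group without the methyl would read, which would separate the effect of the methyl from that of the place of the amine on the ring. Also open, as far as these compounds go, are how a 3-aminopyrrolidin-1-yl group or a longer 3-(2-aminoethyl)piperidin-1-yl chain would stand against these three.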